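The source may report more compounds than this note shows. Statements on the series, on what has been measured and on what is new or still open speak of the compounds shown alone.

Compound 1, `CNC(=O)COc1ccc2c(c1)S(=O)(=O)C=C(c1c(O)c3cc(F)ccc3n(Cc3ccc(F)cc3)c1=O)N2`: > 50000 nM
Compound 2, `CN(c1ccc2c(c1)S(=O)(=O)C=C(c1c(O)c3cc(F)ccc3n(Cc3ccc(F)cc3)c1=O)N2)S(C)(=O)=O`: > 50000 nM

Two compounds of this series have been run in an ADME assay on 2209-23 cells (Homo sapiens) for cytotoxicity, read by WST assay; on this read-out higher numbers stand for lower toxicity in this test and lower numbers for higher toxicity in this test. Compound 1 `CNC(=O)COc1ccc2c(c1)S(=O)(=O)C=C(c1c(O)c3cc(F)ccc3n(Cc3ccc(F)cc3)c1=O)N2` gives > 50000 nM, which is a limit of the assay and not a number. Compound 2 `CN(c1ccc2c(c1)S(=O)(=O)C=C(c1c(O)c3cc(F)ccc3n(Cc3ccc(F)cc3)c1=O)N2)S(C)(=O)=O` gives > 50000 nM, again a limit. Between them lies the step that the two limits leave unreadable from compound 1 to compound 2, and its size is not readable because of the limit of > 50000 nM in this assay, at which 2 of the 2 values shown sit. So compound 2 stands only at a limit in this assay, and the one further value shown is a limit as well.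

Compound 3 `CS(=O)(=O)NCc1ccc2c(c1)S(=O)(=O)C=C(c1c(O)c3cc(F)ccc3n(Cc3ccc(F)cc3)c1=O)N2` has not yet been measured. It differs from compound 2 by (methanesulfonamido)methyl in place of methyl(methylsulfonyl)amino on an aromatic carbon. Going by the values given here, no measured step bears directly on this change, and the single step available, from compound 1 to compound 2, is unreadable. The writer therefore expects compound 3 to sit again at the limit, a step that the limit leaves unreadable from compound 2 to compound 3 of no readable size. The estimate for compound 3 is 80000 nM, with a range from 30000 nM to 300000 nM.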

Compound 3, half-maximal cytotoxic concentration: > 50000 nM
Compound 3: a limit, no number (the forecaster's own chance of this, stated with the estimate: 85%); the middle value is on the limit's open side.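

In this assay compound 3 gives > 50000 nM, a limit of the assay and not a number. No step among compound 1, compound 2 and compound 3 can be read, because all sit at one limit: the limit of > 50000 nM in this assay, at which 3 of the 3 values shown sit.

The compounds shown leave open how far their true values differ in this assay.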